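The source may report more compounds than this note shows. Statements on the series, on what has been measured and on what is new or still open speak of the compounds shown alone.

Working notes on the series.

Three compounds have numbers in an assay for inhibition of protein disulfide-isomerase (Homo sapiens), with a stated time of 1 h; on this read-out lower numbers stand for stronger inhibition and higher numbers for weaker inhibition. Compound 1, `Oc1cc2c(cc1C(c1ccc(F)cc1)N1CCCCC1)OCCO2`, gives 670 nM. Compound 2, `Oc1cc(F)ccc1C(c1ccc2ccoc2c1O)N1CCCCC1`, gives 1070 nM. Compound 3, `Oc1c(C(Nc2ccccn2)c2ccc(Cl)cc2)ccc2cccnc12`, gives 170 nM, the lowest of the three; its gap to compound 1 is the nearest and its gap to compound 2 the widest, and both lie beyond the scatter, so compound 3 is the most potent of the measured set on this assay. Among the measured compounds shown here, no two measured compounds differ in a single place, so no single-point step has been measured; the three structures differ in several places at once and only their bare values can be compared.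

Compound 4, `Oc1c(C(Nc2ccccn2)c2c(Cl)cccc2Cl)ccc2cccnc12`, has not yet been measured. It differs from compound 3 in one place: 2,6-dichlorophenyl in place of 4-chlorophenyl on a saturated chain carbon bound to an aromatic carbon and a nitrogen on an aromatic ring. Nothing in the measured set isolates a change of this kind, so the direction of the step is open. The working expectation for compound 4 is a small step, within or just beyond the scatter, with a slight lean toward a higher number, giving a 1.5-fold higher number from compound 3 to compound 4 (0.17 log units; within the scatter). Compound 4 is therefore estimated at 250 nM in this assay, with a range from 80 nM to 800 nM, to be checked when the value is known.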

Compound 4, half-maximal inhibitory concentration: 1890 nM
Beside the measured number, compound 4's estimate is 7.6-fold (0.88 log units) below it, and the stated range ends below it.
By their numbers in this assay, from the lowest: compound 3; then compounds 1, 2 and 4 (each within the scatter of the next, the first and the last beyond it).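

Among the compounds shown here, the group on the saturated chain carbon bound to an aromatic carbon and a nitrogen on an aromatic ring is the first place with a measured single change, and in this assay that place proves sensitive to the substitution of its ring. Putting 2,6-dichlorophenyl in place of 4-chlorophenyl gives an 11-fold higher number from compound 3 to compound 4 (1.05 log units; beyond the scatter) as a large step beyond the scatter, even though both groups have one six-membered aromatic ring of carbon only, no hydrogen-bond donors or acceptors and no net charge, so a change that leaves these counts untouched can still carry a large penalty here. No evidence in hand bears on the cause of this step.

With a single step at this place, the compounds shown cannot separate the effect of adding chlorine from that of moving it, and they give no reading of how far the sensitivity extends to other groups. Still open, as far as these compounds go, is how a plain phenyl ring, a pyridine ring, or a phenyl ring carrying methoxy or nitrile would behave at this carbon in this assay on the same core.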